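Phenyl to 4-chlorophenyl from compound 3

The source may report more compounds than this note shows. Statements on the series, on what has been measured and on what is new or still open speak of the compounds shown alone.

compound 1 `COc1ccccc1/C=C/C(=O)c1c(O)cc2occc2c1OC` gives 21900 nM
compound 2 `COc1c(C(=O)/C=C/c2ccc(Cl)cc2)c(O)c(Br)c2occc12` gives 3480 nM
compound 3 `C=CCc1c(O)c(C(=O)/C=C/c2ccccc2)c(OC)c2ccoc12` gives 4960 nM

All three values come from a functional assay on TK-10 cells (Homo sapiens) for inhibition, with a stated time of 48 h (on this read-out lower numbers stand for stronger inhibition of growth and higher numbers for weaker inhibition of growth), as the read-out. Compound 3 (4960 nM) lies within the scatter of compound 2, and its number is lower than that of compound 1 by more than the scatter. Compound 4 `C=CCc1c(O)c(C(=O)/C=C/c2ccc(Cl)cc2)c(OC)c2ccoc12` carries chloro in place of hydrogen on an aromatic carbon, para to a large group (chloro in place of hydrogen on an aromatic carbon). Within the data shown here, no measured pair shows this change alone. Among the measured compounds shown here, the only measured compound with a 4-chlorophenyl group is compound 2 (3480 nM), so only a small move toward lower numbers in this assay is expected, possibly none beyond the scatter. The expected change is a 1.4-fold lower number from compound 3 to compound 4 (0.14 log units; within the scatter) in size. For compound 4 the estimated value is 3600 nM with an expected range from 1600 nM to 8000 nM as its limits.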

Compound 4, concentration for 50% growth inhibition: 3620 nM
Compound 4: the middle estimate sits 1.0-fold (0.00 log units) below what was measured; measured number inside the range.
By their numbers in this assay, from the lowest: compounds 2, 4 and 3 (each within the scatter of the next); then compound 1.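

Chloro in place of hydrogen on an aromatic carbon, para to a large group, can now be read as a single change in this assay (a 1.4-fold lower number from compound 3 to compound 4 (0.14 log units; within the scatter)), and phenyl to 4-chlorophenyl does not separate the two compounds. Allyl in place of bromo on an aromatic carbon gives no separation either (a 1.0-fold higher number from compound 2 to compound 4 (0.02 log units; within the scatter)). Neither single change moves the number beyond the scatter.

As far as these compounds go, whether an amine in place of the chloro, or a longer chain in place of the allyl, would do so remains open. No measurement offers an explanation for these values.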